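Fluoro to nitro: working notes on compound 4

The compounds below may be only part of what the source reports. "The series", "measured", "known", "first", "only" and "open" are said of these compounds alone.

Measured so far in a functional assay on KB cells (Homo sapiens) for cytotoxicity; on this read-out higher numbers stand for weaker inhibition and lower numbers for stronger inhibition
- compound 1 `COc1ccc(S(=O)(=O)N2CCc3cccc(NS(=O)(=O)c4ccc(F)cc4)c32)cc1` gives 1200 nM
- compound 2 `COc1ccc(S(=O)(=O)N2CCc3cccc(NC(=O)c4ccc(F)cc4)c32)cc1` gives 93 nM
- compound 3 `COc1ccc(S(=O)(=O)N2CCc3cccc(NC(=O)N(C)c4ccccc4)c32)cc1` gives > 10000 nM which is a limit, not a number

Of the two actual numbers, compound 1 holds the higher, with a 13-fold lower number from compound 1 to compound 2 (1.11 log units; beyond the scatter) as the gap. Compound 4 `COc1ccc(S(=O)(=O)N2CCc3cccc(NS(=O)(=O)c4ccc([N+](=O)[O-])cc4)c32)cc1` keeps everything in compound 1 except one group, nitro in place of fluoro on an aromatic carbon with nitro in place of fluoro on an aromatic carbon, para to a large group. The measured steps bear on this only indirectly. Both a 13-fold lower number from compound 1 to compound 2 (1.11 log units; beyond the scatter) and an at least 8.3-fold higher number from compound 1 to compound 3 (0.92 log units; beyond the scatter) replace the whole (4-fluorophenyl)sulfonyl group, and neither changes the fluoro group alone. Among the measured compounds shown here, no measured step isolates that substituent, so no step beyond the scatter is expected in this assay and the range stays wide. The expected change is a 1.5-fold higher number from compound 1 to compound 4 (0.18 log units; within the scatter) in this estimate. For compound 4 the estimated value is 1800 nM with an expected range of 500 nM to 7000 nM as the working figure.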

Compound 4, half-maximal inhibitory concentration: 1100 nM
Estimate against measurement, compound 4: 1.6-fold (0.21 log units) above, and the stated range covers the measured number.
By their numbers in this assay, from the lowest: compound 2; then compounds 4 and 1 (each within the scatter of the next). At a limit, above all of these: compound 3.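

Among the compounds shown here, the step of a 1.1-fold lower number from compound 1 to compound 4 (0.04 log units; within the scatter) in this assay is the first to change only the substituent on the aromatic carbon, para to a large group, while the rest of the (4-fluorophenyl)sulfonyl group stays in place. Fluoro and nitro, with one and three heavy atoms, are thus not told apart on this read-out at this position, whereas the earlier steps, which replace the whole (4-fluorophenyl)sulfonyl group, all lie beyond the scatter. Nothing shown gives a reason for this lack of separation.

On these data alone, two substituents do not define the tolerance of this position, so it remains open whether an amine or a carboxylic acid there would stay within the scatter of compound 1. As far as these compounds go, it also remains open whether nitro in place of fluoro would read the same on compound 2.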